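A Halogen Swap Among Compounds at the Assay Limit

This account rests on a few compounds, and the source may have more. Where it says the series, first, only, none or still open, it means among the compounds named here.

Compound 1, `CC#CCn1c(N2CCC[C@@H](N)C2)nc2c1c(=O)n(Cc1c(Br)cccc1C(=O)O)c(=O)n2C`, was tested in an ADME assay on isolated protein for inhibition of Dipeptidyl peptidase 9 (Homo sapiens), with stated times of 15 min, 60 s and 20 min; on this read-out lower numbers stand for stronger inhibition and higher numbers for weaker inhibition. In this assay compound 1 returns only a limit, > 100000 nM, so no number is known for it. Two related compounds share that outcome. Compound 2, `CC#CCn1c(N2CCC[C@@H](N)C2)nc2c1c(=O)n(Cc1cc(C#N)ccc1C(=O)O)c(=O)n2C`, gives the limit > 100000 nM in this assay. Compound 3, `CC#CCn1c(N2CCC[C@@H](N)C2)nc2c1c(=O)n(Cc1ccccc1C(=O)OC)c(=O)n2C`, gives the limit > 100000 nM in this assay. Because every value sits at the limit of > 100000 nM in this assay, at which 3 of the 3 values shown sit, none of the steps between them can be read: there is a step that the two limits leave unreadable from compound 1 to compound 2, a step that the two limits leave unreadable from compound 1 to compound 3 and a step that the two limits leave unreadable from compound 2 to compound 3. Compound 1 therefore stands at the same limit as its two companions, with nothing to set it apart.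

The compound still to be measured is compound 4, `CC#CCn1c(N2CCC[C@@H](N)C2)nc2c1c(=O)n(Cc1c(Cl)cccc1C(=O)O)c(=O)n2C`. It differs from compound 1 in one place: chloro in place of bromo on an aromatic carbon. The measured steps all concern the group on the saturated chain carbon bound to the aromatic nitrogen, and every one of them is unreadable, so they offer neither a direction nor a size to expect in this assay. With all neighbours at the limit, compound 4 is expected to show a step that the limit leaves unreadable from compound 1 to compound 4, which in practice means none that can be read. Compound 4 is thus estimated at 150000 nM in this assay, within a range from 50000 nM to 500000 nM, most likely reported once more only as a limit.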

Compound 4, half-maximal inhibitory concentration: > 100000 nM
Compound 4 was reported as a limit (the forecaster's own chance of this, stated with the estimate: 90%); the middle value lies beyond the limit too.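

Compound 4 is also reported only as a limit, so no step from compound 1, compound 2 or compound 3 to compound 4 can be read, including the exchange of bromo for chloro: the limit of > 100000 nM in this assay, at which 4 of the 4 values shown sit.

The compounds shown leave open what number lies behind each limit, and whether chloro and bromo differ at all.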